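A few compounds are considered here, and "the series" means these few. Any claim that something is new, unique, unknown or untested is made for them only; others in the source may bear on it.

Working notes on the series. Of the compounds shown here, three have been measured in a functional assay on MCF7 cells (Homo sapiens) for cytotoxicity, read by MTT assay, with a stated time of 72 h; on this read-out higher numbers stand for weaker inhibition and lower numbers for stronger inhibition. Compound 1 `CNC(=O)c1cc(Oc2ccc(NC(=O)c3nn(-c4ccc(Br)cc4F)c(=O)cc3C)cc2F)ccn1` gives 9360 nM. Compound 2 `Cc1cc(=O)n(-c2ccccc2C(F)(F)F)nc1C(=O)Nc1ccc(Oc2ncnc3ccsc23)cc1` gives 5550 nM. Compound 3 `Cc1cc(=O)n(-c2ccc(Br)cc2F)nc1C(=O)Nc1ccc(Oc2ncnc3ccsc23)cc1` gives 9360 nM, level with compound 1 at the digits shown; together these two carry the highest numbers of the three, with compound 2 the lowest, though the step of a 1.7-fold higher number from compound 2 to compound 3 (0.23 log units; within the scatter) stays within the scatter, so no ordering is claimed.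

The next compound, compound 4 `Cc1cc(=O)n(-c2ccc(Br)cc2F)nc1C(=O)Nc1ccc(Oc2ncnc3ccsc23)c(F)c1`, differs from compound 3 by fluoro in place of hydrogen on an aromatic carbon. For the measured compounds named here, no measured step covers this change on the shared core: the only single-change step, from compound 2 to compound 3, concerns the aryl group on the aromatic nitrogen and was small. Compound 1 also bears a fluoro substituent but differs elsewhere too, so its value and that of compound 3 show only that the two stand level. With nothing pointing either way, the expectation for this assay is a step of a 1.0-fold lower number from compound 3 to compound 4 (0.02 log units; within the scatter) of no size beyond the scatter. Compound 4 is therefore estimated at 9000 nM, in the range 3500 nM to 25000 nM.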

Compound 4, half-maximal inhibitory concentration: 1550 nM
Compound 4: middle estimate off by 5.8-fold (0.76 log units), on the high side, outside the stated range (below it).
By their numbers in this assay, from the lowest: compound 4; then compounds 2, 1 and 3 (each within the scatter of the next).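

In this assay fluoro in place of hydrogen on an aromatic carbon gives a 6.0-fold lower number from compound 3 to compound 4 (0.78 log units; beyond the scatter) and so stands beyond the scatter, whereas the change of aryl group on the aromatic nitrogen gave a 1.7-fold higher number from compound 2 to compound 3 (0.23 log units; within the scatter) and stayed within it. With the fluoro present in both compounds, the group on the oxygen also matters, as the exchange of a group of 10 heavy atoms for a group of 9 heavy atoms gives a 6.0-fold lower number from compound 1 to compound 4 (0.78 log units; beyond the scatter) in the same assay. Nothing measured on these compounds accounts for either step.

As far as these compounds go, whether the lower number is specific to fluoro remains open, since chloro, methoxy or an amine on the same aromatic carbon could give a different result. From the compounds shown here alone, it is also open whether the fluoro step carries over to compounds bearing the 2-(trifluoromethyl)phenyl group of compound 2.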